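A few compounds are considered here, and "the series" means these few. Any claim that something is new, unique, unknown or untested is made for them only; others in the source may bear on it.

For the measured compounds named here, compound 1 `CCc1sc(CCc2cc(OC)cc(NCc3cc(Cl)cc(NC(=O)OC(C)C)c3)n2)nc1C` is the weakest binder of the three measured members: in an assay on cells for binding affinity to Neuropeptide Y receptor type 1 (Homo sapiens) (a lower number here means a stronger inhibitor, a higher number a weaker inhibitor), compound 1 gives 234 nM, the highest number of the three. Compound 2 `CCCCOc1cc(CCc2nc(C)c(CC)s2)nc(NCc2cc(Cl)cc(NC(=O)OC(C)C)c2)c1` gives 16 nM in this assay, and compound 3 `CCc1sc(CCc2cc(OC3CCCC3)cc(NCc3cc(Cl)cc(NC(=O)OC(C)C)c3)n2)nc1C` gives 11 nM. The two steps away from compound 1 are both large: a 15-fold lower number from compound 1 to compound 2 (1.17 log units; beyond the scatter) and a 21-fold lower number from compound 1 to compound 3 (1.33 log units; beyond the scatter). Between compounds 2 and 3 the numbers sit close together, a 1.5-fold lower number from compound 2 to compound 3 (0.16 log units; within the scatter).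

Compound 4 `CCc1sc(CCc2cc(OCCc3ccccc3)cc(NCc3cc(Cl)cc(NC(=O)OC(C)C)c3)n2)nc1C` extends the same position of the shared core: benzyl in place of hydrogen on a saturated chain carbon bound to an oxygen on an aromatic ring. Both measured steps that enlarge the group at this position, from compound 1 to compound 2 and from compound 1 to compound 3, lowered the number strongly, so a step of similar size and direction is expected for compound 4 in this assay, namely a 16-fold lower number from compound 1 to compound 4 (1.19 log units; beyond the scatter). For compound 4 the estimate is 15 nM, with a range from 5 nM to 50 nM. Going by these compounds, whether a benzyl extension behaves like propyl or cyclopentyl is untested here.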

Compound 4, half-maximal inhibitory concentration: 30 nM
For compound 4 the middle estimate is 2.0-fold (0.30 log units) below the measured one, within the range that was stated.
By their numbers in this assay, from the lowest: compounds 3, 2 and 4 (each within the scatter of the next, the first and the last beyond it); then compound 1.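

In this assay phenethyl on the oxygen still lowers the number relative to methyl (a 7.8-fold lower number from compound 1 to compound 4 (0.89 log units; beyond the scatter)), so a terminal six-membered aromatic ring is accepted at this position, but this step is modest where the steps to butyl and cyclopentyl were large. Phenethyl gives a modestly higher number than cyclopentyl (a 2.7-fold higher number from compound 3 to compound 4 (0.44 log units; beyond the scatter)), whereas phenyl in place of the terminal ethyl of the butyl chain leaves the two values within the scatter (a 1.9-fold higher number from compound 2 to compound 4 (0.27 log units; within the scatter)). The larger groups therefore do not separate into a clean order: only compound 3 and compound 4 stand apart, and compound 2 cannot be told from either.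

Going by these compounds, whether an amine or a carboxylic acid at the end of the chain, or a longer phenylpropyl chain, would keep these numbers remains open. No measurement at hand bears on the reason for these differences.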